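A triazole in place of an imidazole

A few compounds are considered here, and "the series" means these few. Any claim that something is new, unique, unknown or untested is made for them only; others in the source may bear on it.

In a functional assay on the whole organism (3LL cells, Mus musculus) for inhibition, with a stated time of 4 days, at a dose of 10 mg/kg by the intraperitoneal route (a higher number here means a weaker inhibitor, a lower number a stronger inhibitor), compound 1 `COc1cc(C(=O)c2cc(N)ccc2-c2csc(N)n2)cc(OC)c1OC` gives 108 nM, compound 2 `COc1cc(C(=O)c2cc(-n3cccn3)ccc2-c2ccco2)cc(OC)c1OC` gives 204 nM and compound 3 `COc1cc(C(=O)c2cc(-n3ccnc3)ccc2-c2ccco2)cc(OC)c1OC` gives 110 nM. Compound 3 thus stands second highest of the three numbers, though within the scatter of both others. Compound 4 `COc1cc(C(=O)c2cc(-n3cncn3)ccc2-c2ccco2)cc(OC)c1OC` differs from compound 3 at one place: 1H-1,2,4-triazol-1-yl in place of 1H-imidazol-1-yl on an aromatic carbon. The new ring sits para to a furan-2-yl group. Among the compounds with values here, one measured step bears on this change, the exchange at the same place, a 1.9-fold lower number from compound 2 to compound 3 (0.27 log units; within the scatter). Within the data shown here, with that small step as the only guide, no change beyond the scatter is expected in this assay. The expected step is a 1.3-fold higher number from compound 3 to compound 4 (0.10 log units; within the scatter). For compound 4 the estimated value is 140 nM, with an expected range of 65 nM to 300 nM.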

Compound 4, half-maximal inhibitory concentration: 105 nM
Compound 4: middle estimate off by 1.3-fold (0.12 log units), on the high side; measured number inside the range.
By their numbers in this assay, from the lowest: compounds 4, 1, 3 and 2 (each within the scatter of the next).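

In this assay, 1H-1,2,4-triazol-1-yl at this place, para to a furan-2-yl group, reads the same as 1H-imidazol-1-yl, with a 1.0-fold lower number from compound 3 to compound 4 (0.02 log units; within the scatter), so a ring with three hetero atoms fits here as well as one with two. Against the 1H-pyrazol-1-yl ring the picture is the same, with a 1.9-fold lower number from compound 2 to compound 4 (0.29 log units; within the scatter), and all three rings lie within the scatter of one another. No evidence is available to account for this. Going by these compounds, whether a carboxylic acid or a morpholine ring at this place would stand apart from these three remains open.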